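Methyl on the aniline ring: from compound 3 to compound 4

The source may hold more compounds than are shown below. What is called first, only, known or untested is meant among the compounds shown, and "the series" means these compounds.

Measured in a functional assay on the whole organism (strain Kunming) for inhibition, with Mus musculus as the target, in the writhing test, with stated times of 1 h and 15 min, at a dose of 200 mg/kg by the oral route; a higher number here means more inhibition at the dose given (going by the name of the read-out), a lower number less inhibition:
Compound 1 `CN(CC1CCC/C(=C\c2ccccc2)C1=O)c1ccccc1`: 69.7%
Compound 2 `Cc1ccc(N(C)CC2CCC/C(=C\c3ccccc3)C2=O)cc1`: 81%
Compound 3 `Cc1ccc(/C=C2\CCCC(CN(C)c3ccccc3)C2=O)cc1`: 68.2%

Compound 3 holds the lowest of the three numbers, but its gap to compound 1 is within the scatter, so these two cannot be ordered against each other. Compound 2 lies beyond the scatter above compound 3, as the two values show. Among the compounds with values here, of the measured steps, a number 1.5 percentage points lower from compound 1 to compound 3 (within the scatter) is the one that leads to compound 3, and it stays within the scatter.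

Compound 4 `Cc1ccc(/C=C2\CCCC(CN(C)c3ccc(C)cc3)C2=O)cc1` differs from compound 3 by methyl in place of hydrogen on an aromatic carbon. The same change, made on compound 1, gave a number 11.3 percentage points higher from compound 1 to compound 2 (beyond the scatter), a modest rise beyond the scatter. Within the data shown here, that is the only measured step that bears on the change in hand; the other step, a number 1.5 percentage points lower from compound 1 to compound 3 (within the scatter), concerns the other ring and is not comparable. One bearing step is a thin basis, but it points in one direction. Compound 4 is therefore expected to show a number 9.8 percentage points higher from compound 3 to compound 4 (within the scatter) in this assay. The estimate for compound 4 is 78%, with a range from 66% to 89%.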

Compound 4, a percentage reported as inhibition, in the whole organism at one dose (the size of the read-out at that dose, not a potency): 76.6%
For compound 4 the middle estimate is 1.4 percentage points above the measured one; measured number inside the range.
By their numbers in this assay, from the lowest: compounds 3, 1, 4 and 2 (each within the scatter of the next, the first and the last beyond it).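

Notes on the methyl at the aniline ring. In this assay, phenyl to 4-methylphenyl on a core that already carries the other ring's methyl gives a number 8.4 percentage points higher from compound 3 to compound 4 (within the scatter), so on this core the step alone does not clear the scatter, whereas on the core of compound 1 it did. Read across both cores, the size of the change at this place holds up, which is the new information from this compound: the same change on two cores in this assay, a number 11.3 percentage points higher (beyond the scatter) from compound 1 to compound 2 and a number 8.4 percentage points higher (within the scatter) from compound 3 to compound 4, 2.9 percentage points apart, within the scatter of two such steps Methyl on the other ring, now tested with the aniline ring already methylated, gives a number 4.4 percentage points lower from compound 2 to compound 4 (within the scatter), so it remains without a readable effect on either core: the same change on two cores in this assay, a number 1.5 percentage points lower (within the scatter) from compound 1 to compound 3 and a number 4.4 percentage points lower (within the scatter) from compound 2 to compound 4, 2.9 percentage points apart, within the scatter of two such steps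

The compounds shown leave open whether the step is particular to methyl or would also appear with chlorine, methoxy or a longer chain such as ethyl at this place, para to a large group. The read-out at one oral dose gives the size of the inhibition at that dose and not a potency, so the ordering of these compounds at other doses also stays open.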